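From Cyclohexyl to Methyl: Expected Stability of Compound 4

A few compounds are considered here, and "the series" means these few. Any claim that something is new, unique, unknown or untested is made for them only; others in the source may bear on it.

Of the compounds shown here, three built on one shared core have been tested in a physicochemical assay for metabolic stability, read by LC-MS, in phosphate buffer, with a stated time of 3 h, at pH 7.4, tested at 50 uM; a higher number here means that more of the compound is left, a lower number that less of the compound is left. Compound 1 `CCOC(=O)C1=C(S[C@@H]2CN[C@H](C(=O)Nc3cccc(C(=O)O)c3)C2)[C@H](C)[C@@H]2[C@@H]([C@@H](C)O)C(=O)N12` gives > 95%, which is a limit of the assay rather than a measured number. Compound 2 `CCOC(=O)OCOC(=O)C1=C(S[C@@H]2CN[C@H](C(=O)Nc3cccc(C(=O)O)c3)C2)[C@H](C)[C@@H]2[C@@H]([C@@H](C)O)C(=O)N12` gives > 95%, again a limit. Compound 3 `C[C@@H](O)[C@H]1C(=O)N2C(C(=O)OCOC(=O)OC3CCCCC3)=C(S[C@@H]3CN[C@H](C(=O)Nc4cccc(C(=O)O)c4)C3)[C@H](C)[C@H]12` gives > 95%, also a limit. Within the data shown here, compound 3 thus stands exactly where the other two stand, at the limit of > 95% in this assay, at which 3 of the 3 values shown sit, and no compound can be ranked above another. Among the measured compounds shown here, for the same reason the measured steps a step that the two limits leave unreadable from compound 1 to compound 2, a step that the two limits leave unreadable from compound 1 to compound 3 and a step that the two limits leave unreadable from compound 2 to compound 3 cannot be given a size; they show only that every member of the set stayed almost entirely intact over the stated time.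

Compound 4 `COC(=O)OCOC(=O)C1=C(S[C@@H]2CN[C@H](C(=O)Nc3cccc(C(=O)O)c3)C2)[C@H](C)[C@@H]2[C@@H]([C@@H](C)O)C(=O)N12` is the next member. Compared with compound 3 the change is methyl in place of cyclohexyl on an oxygen next to a carbonyl group. The step from compound 2 to compound 3 changed the same oxygen-bound group, from ethyl to cyclohexyl, without any readable effect because both ends sit at the limit of > 95% in this assay, at which 3 of the 3 values shown sit. Nothing in the measured set points toward a loss of stability when that group is made smaller again, so the step that the limit leaves unreadable from compound 3 to compound 4 is expected to be none beyond the scatter. Compound 4 is therefore expected to give 97% in this assay, within a range from 90% to 100%.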

Compound 4, percent of the compound remaining: > 95%
Compound 4 ended at the assay's limit; the forecaster's own chance of this, stated with the estimate: 85%; the middle value is on the limit's open side.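

The steps to compound 4 from compound 1, compound 2 and compound 3 cannot be read in this assay because each value is a limit and not a number: the limit of > 95% in this assay, at which 4 of the 4 values shown sit.

The compounds shown leave open how far their stability really differs, and which change, if any, would bring a value away from the limit.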